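Shortening the amine-bearing chain in the shared core

The source may hold more compounds than are shown below. What is called first, only, known or untested is meant among the compounds shown, and "the series" means these compounds.

Measured compounds in a functional assay on HT-29 cells (Homo sapiens) for cytotoxicity, read by MTT assay, with a stated time of 2 days, tested at 10 uM; a higher number here means more inhibition at the concentration tested (going by the name of the read-out), a lower number less inhibition:
- compound 1 `CN(C)CCCNc1nc(NCc2ccco2)c2ccccc2n1`: "not determined" (no result reported)
- compound 2 `COc1ccc(Nc2nc(NCc3ccco3)c3cc(F)ccc3n2)cc1`: 86.2%

Compound 1 stands nowhere on the numbers, as this assay reports no result for it. Among the measured compounds shown here, compound 2 gives a result in this assay, but no step between compound 1 and compound 2 is defined, so its value only shows what one member of the series reaches. The move to compound 3 `CN(C)CCNc1nc(NCc2ccco2)c2ccccc2n1` is dimethylamino in place of (dimethylamino)methyl on a saturated chain carbon, two bonds along the chain from a nitrogen on an aromatic ring. For the measured compounds named here, with no measured step, no size or direction beyond the scatter can be expected for this change. Compound 3 is expected to give about 60% in this assay, within a range of 20% to 95%.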

Compound 3, a percentage reported as inhibition, at one concentration (the size of the read-out at that concentration, not a potency): 21.7%
For compound 3 the middle estimate is 38.3 percentage points above the measured one; the measured number falls inside the stated range.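

In this assay, among the compounds shown here, compound 3 gives 21.7% while compound 1 gives "not determined" (no result reported) and so no step between the two can be read. The compounds shown leave open how shortening the amine-bearing chain bears on inhibition. No evidence on this result is available.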